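Cytotoxicity notes: methoxycarbonyl in place of carbamoyl

The source may report more compounds than this note shows. Statements on the series, on what has been measured and on what is new or still open speak of the compounds shown alone.

Compound 1 `COc1ccc(NC(=O)Nc2cc(C)nc3ccccc23)cc1`: in an ADME assay on HepG2 cells (Homo sapiens) for cytotoxicity, with a stated time of 72 h (a higher number here means that more compound is needed for the effect, a lower number that less compound is needed), compound 1 gives > 25000 nM, a limit of the assay.
Compound 2 `Cc1cc(NC(=O)Nc2ccc(C(=O)O)cc2)c2ccccc2n1`: in this assay compound 2 gives > 25000 nM, a limit of the assay.
Compound 3 `Cc1cc(NC(=O)Nc2cccc(C(N)=O)c2)c2ccccc2n1`: in this assay compound 3 gives > 25000 nM, a limit of the assay.

Compound 3 therefore stands at the same limit as every other measured member of the series, since (the limit of > 25000 nM in this assay, at which 3 of the 3 values shown sit). Going by the values given here, the one step between measured compounds that differ in one place, a step that the two limits leave unreadable from compound 1 to compound 2, cannot be read because both ends are limits, so no measured step tells how far a change on the outer ring moves the read-out.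

Compound 4 `COC(=O)c1cccc(NC(=O)Nc2cc(C)nc3ccccc23)c1` is the next member. It differs from compound 3 as follows: methoxy in place of amino on a carbonyl carbon. Among the compounds with values here, no measured step bears on this change directly, and the only one recorded is unreadable, so nothing in the data points either way. Given that compound 3 sits at the limit, the step that the limit leaves unreadable from compound 3 to compound 4 is expected to stay within the scatter, and compound 4 is estimated at 30000 nM in this assay, between 8000 nM and 100000 nM, most likely reported again as a limit.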

Compound 4, half-maximal effective concentration: 23000 nM
Beside the measured number, compound 4's estimate is 1.3-fold (0.12 log units) above it, and the stated range covers the measured number.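

Going by these compounds alone, with methoxycarbonyl in place of carbamoyl, this assay gives the first reading that is not a limit: compound 4 gives 23000 nM. The change yields an at least 1.0-fold lower number from compound 3 to compound 4 (0.03 log units; that floor lies within the scatter); this is only a floor, as one end of the step is a limit, so the true size may be larger than the printed figure. Every other member shown stays at the limit: the limit of > 25000 nM in this assay, at which 3 of the 4 values shown sit.

On these data alone, whether the measurable reading belongs to the ester as such stays open, and an ethyl ester, a ketone or a nitrile in place of the methoxycarbonyl group would test this. Also open is whether methoxycarbonyl reads the same on another carbon of the outer ring, since the compounds shown carry it in one place only.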